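The source may hold more compounds than are shown below. What is called first, only, known or untested is meant among the compounds shown, and "the series" means these compounds.

In a functional assay (strain AB) with Danio rerio as the target, read by microscopy, with a stated time of 1 h (a higher number here means that more compound is needed for the effect, a lower number that less compound is needed), compound 1 `CCN1CCc2c(sc(NC(=O)NCC3CCCO3)c2C(N)=O)C1` gives > 25000 nM, which is a limit of the assay and not a number. Compound 2 `CCN1CCc2c(sc(NC(=O)Nc3cccc(C#N)c3)c2C(N)=O)C1` gives 10300 nM and compound 3 `CCN1CCc2c(sc(NC(=O)Nc3ccc(Cl)cc3Cl)c2C(N)=O)C1` gives 11500 nM, and these two sit level: a 1.1-fold higher number from compound 2 to compound 3 (0.05 log units; within the scatter). Compound 4 `CCN1CCc2c(sc(NC(=O)CN3CCCCC3)c2C(N)=O)C1` has not yet been measured, and it differs from compound 1 as follows: (piperidin-1-yl)methyl in place of ((oxolan-2-yl)methyl)amino on a carbonyl carbon. The nearest evidence is an at least 2.4-fold lower number from compound 1 to compound 2 (0.38 log units; beyond the scatter) and an at least 2.1-fold lower number from compound 1 to compound 3 (0.33 log units; beyond the scatter), steps that bring in 3-cyanophenyl or 2,4-dichlorophenyl on an amide-type nitrogen, and compound 4 carries neither group, so only a small lowering, perhaps none beyond the scatter, is expected in this assay. The estimated step is an at least 1.2-fold lower number from compound 1 to compound 4 (0.09 log units; that floor lies within the scatter). For compound 4 the estimate is 20000 nM, with an expected range from 9000 nM to 35000 nM.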

Compound 4, half-maximal effective concentration: > 25000 nM
Compound 4 was reported as a limit (the forecaster's own chance of this, stated with the estimate: 50%); middle value at least 1.2-fold (0.09 log units) from the limit.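

Compound 1 and compound 4 both sit at a limit of this assay, not at a number, so the step between them cannot be read. The compounds shown leave open whether (piperidin-1-yl)methyl in place of ((oxolan-2-yl)methyl)amino changes the number at all.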